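The source may report more compounds than this note shows. Statements on the series, on what has been measured and on what is new or still open speak of the compounds shown alone.

Working notes on the series.

Among the compounds with values here, compound 2 `CC[C@@H]1C(=O)N(C)c2cnc(-n3ccc4cc(C(=O)NC5CCCC5)ccc43)nc2N1C1CCCC1` is the only member of the set with a numerical result: in a functional assay on Huh-7 cells (Homo sapiens) for antiproliferative activity, read by CCK-8 assay, with a stated time of 72 h (on this read-out higher numbers stand for weaker inhibition of growth and lower numbers for stronger inhibition of growth), compound 2 gives 259 nM. Compound 1 `CCC1C(=O)N(C)c2cnc(Nc3ccc(S(=O)(=O)NCCCO)cc3)nc2N1c1ccn(C)n1` is recorded in this assay as "not active" (no number reported), with no number attached. Compound 3 `CCC1C(=O)N(C)c2cnc(Nc3ccc(S(N)(=O)=O)cc3)nc2N1c1ccn(C)n1` is likewise recorded in this assay as "not active" (no number reported), again without a number. Within the data shown here, both compound 1 and compound 3 share an anilino-type linkage to the core that compound 2 does not carry, so neither offers a step of one change against compound 2, and no such step is available in the set.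

Compound 4 `CCCNC(=O)c1ccc2c(ccn2-c2ncc3c(n2)N(C2CCCC2)[C@H](CC)C(=O)N3C)c1` has not been measured. It differs from compound 2 in one place: propyl in place of cyclopentyl on an amide-type nitrogen.

Among the measured compounds shown here, no measured pair isolates this change, so the size of its effect in this assay cannot be read from the data. The expectation is a small loss of growth inhibition for compound 4, at the edge of the usual scatter rather than clearly beyond it; the step is estimated as a 2.0-fold higher number from compound 2 to compound 4 (0.30 log units; within the scatter). Compound 4 is therefore expected to give 520 nM in this assay, within a range of 200 nM to 1500 nM.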

Compound 4, concentration for 50% growth inhibition: 689 nM
Estimate against measurement, compound 4: 1.3-fold (0.12 log units) below, and the stated range covers the measured number.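

The change from cyclopentyl to propyl on the amide-type nitrogen now has a measured size in this assay: a 2.7-fold higher number from compound 2 to compound 4 (0.42 log units; beyond the scatter). Within the data shown here, this is the first sign that the group on this nitrogen affects the read-out, as the earlier compounds offered no step of one change. The step is modest, and growth inhibition remains measurable as a number with the open propyl chain in place of the ring, although this rests on one pair and no evidence is available to explain the difference.

A single pair cannot separate the loss of the ring from the shorter carbon chain: a pentyl chain on this nitrogen would address that, while a cyclobutyl or cyclohexyl group would show how ring size behaves and an amine or carboxylic acid at the end of the chain would test a very different kind of group. Compound 1 and compound 3 differ from compound 2 and compound 4 in more than one place, so their entries give no reading on this position.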